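This account rests on a few compounds, and the source may have more. Where it says the series, first, only, none or still open, it means among the compounds named here.

In a functional assay on HL-60 cells (Homo sapiens) for inhibition, read by CCK-8 assay, with a stated time of 48 h (on this read-out lower numbers stand for stronger inhibition and higher numbers for weaker inhibition), compound 1 `COc1ccc(S(=O)(=O)Oc2ccccc2/C=C(\C#N)C(=O)Nc2nnc(Cc3ccccc3)s2)cc1` gives 3170 nM and compound 2 `COc1ccc(S(=O)(=O)Oc2ccccc2/C=C(\C#N)C(=O)Nc2nnc(Cc3ccc(Cl)cc3)s2)cc1` gives 4360 nM, so these two values lie within the scatter of each other. Compound 3 `COc1ccc(S(=O)(=O)Oc2ccccc2/C=C(\C#N)C(=O)Nc2nnc(Cc3ccc(C)cc3)s2)cc1` differs from compound 2 by methyl in place of chloro on an aromatic carbon. Going by the values given here, the only measured step at that place is a 1.4-fold higher number from compound 1 to compound 2 (0.14 log units; within the scatter), chloro in place of hydrogen, and it lies within the scatter. On this single step, no change beyond the scatter is expected in this assay. The expected step is a 1.2-fold lower number from compound 2 to compound 3 (0.10 log units; within the scatter). For compound 3 the estimated value is 3500 nM, with an expected range from 1700 nM to 7000 nM.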

Compound 3, half-maximal inhibitory concentration: 4080 nM
For compound 3 the middle estimate is 1.2-fold (0.07 log units) below the measured one; the range from low to high includes it.
By their numbers in this assay, from the lowest: compounds 1, 3 and 2 (each within the scatter of the next).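

In this assay the step to methyl reads as a 1.1-fold lower number from compound 2 to compound 3 (0.03 log units; within the scatter), and against the unsubstituted benzyl as a 1.3-fold higher number from compound 1 to compound 3 (0.11 log units; within the scatter). Hydrogen, chloro and methyl at this position are therefore all within the scatter of each other, so a second substituent now shows no change beyond it. No evidence on the reason is available. Still open, on these data alone, is whether a different kind of group here, such as an amine, a carboxylic acid or a longer alkyl chain, would move the number beyond the scatter.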